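Swapping the Pendant Ring: Forecasting Compound 4

The source may hold more compounds than are shown below. What is called first, only, known or untested is meant among the compounds shown, and "the series" means these compounds.

Measured so far:
- compound 1 `CCCS(=O)(=O)Nc1ccc(F)c(C(=O)c2n[nH]c3ncc(-c4cccc(Cl)c4)cc23)c1F`: 40%
- compound 2 `CCCS(=O)(=O)Nc1ccc(F)c(C(=O)c2n[nH]c3ncc(-c4ccccc4F)cc23)c1F`: 2%
- compound 3 `CCCS(=O)(=O)Nc1ccc(F)c(C(=O)c2n[nH]c3ncc(-c4ccccc4O)cc23)c1F`: 9%

All three compounds share the same core and differ only in the ring that hangs from it. In an assay for binding affinity to dual specificity mitogen-activated protein kinase kinase 4 (Homo sapiens), read by KINOMEscan, tested at 100 nM (on this read-out higher numbers stand for a weaker effect at the one concentration tested and lower numbers for a stronger effect), compound 3 gives 9%, the second highest of the three numbers; the step of a number 7 percentage points higher from compound 2 to compound 3 (within the scatter) is within the scatter, while the step of a number 31 percentage points lower from compound 1 to compound 3 (beyond the scatter) is large. The step of a number 38 percentage points lower from compound 1 to compound 2 (beyond the scatter) is also large, so both rings carrying a substituent at the 2-position read as much stronger binders than the 3-chlorophenyl of compound 1.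

Compound 4 `CCCS(=O)(=O)Nc1ccc(F)c(C(=O)c2n[nH]c3ncc(-c4ccc(N(C)C)cc4)cc23)c1F` is not yet measured. It changes compound 3 as follows: 4-(dimethylamino)phenyl in place of 2-hydroxyphenyl on an aromatic carbon. Among the compounds with values here, no measured step involves a 4-(dimethylamino)phenyl ring, so the three steps bear on it only loosely: they show that exchanging this ring can move the read-out a great deal, in either direction. The estimate therefore allows a rise, though the low readings of compounds 2 and 3 keep it from sitting high. For compound 4 the expected step is a number 11 percentage points higher from compound 3 to compound 4 (beyond the scatter). The expected value for compound 4 in this assay is 20%, with an estimated range from 3% to 55%.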

Compound 4, a percentage reported as activity, at one concentration (the size of the read-out at that concentration, not a potency): 2.5%
Compound 4: the middle estimate sits 17.5 percentage points above what was measured; the measured number lies below the stated range.
By their numbers in this assay, from the lowest: compounds 2, 4 and 3 (each within the scatter of the next); then compound 1.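

In this assay, the 4-(dimethylamino)phenyl ring reads alongside the 2-fluorophenyl and 2-hydroxyphenyl rings, with a number 6.5 percentage points lower from compound 3 to compound 4 (within the scatter) and a number 0.5 percentage points higher from compound 2 to compound 4 (within the scatter), while a number 37.5 percentage points lower from compound 1 to compound 4 (beyond the scatter) is large. Within the data shown here, this position therefore tolerates more than the earlier compounds showed: a low reading does not depend on the 2-substituted rings, and the ring of compound 4, with 9 heavy atoms and 0 hydrogen-bond donors, sits within the scatter of the 2-hydroxyphenyl ring, with 7 heavy atoms and 1 donor, leaving compound 1 as the only one of the four that stands apart. No measurement shown explains why these three rings read alike.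

On these data alone, it remains open whether the nitrogen of the dimethylamino group matters at all, which an unsubstituted phenyl ring or a 4-methoxyphenyl ring would test. A carboxylic acid or a morpholine on the same ring would show how far this tolerance extends.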